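Shrinking the para group: isopropyl to chloro

The compounds below may be only part of what the source reports. "The series", "measured", "known", "first", "only" and "open" are said of these compounds alone.

Compound 1 `Cc1nc2cc(OC[C@H](O)CN3CCN(Cc4noc(-c5ccc(C(C)(C)C)cc5)n4)CC3)ccc2s1`: 180 nM
Compound 2 `Cc1nc2cc(OC[C@H](O)CN3CCN(Cc4noc(-c5ccc(C(C)C)cc5)n4)CC3)ccc2s1`: 950 nM

In a functional assay on mitochondria from heart for inhibition of peroxisomal acyl-coenzyme A oxidase 1 (Rattus norvegicus) (a lower number here means a stronger inhibitor, a higher number a weaker inhibitor), compound 2 gives the higher of the two numbers, the weaker inhibition. Among the compounds with values here, the single measured step, a 5.3-fold higher number from compound 1 to compound 2 (0.72 log units; beyond the scatter), came from removing one methyl from the group on the phenyl ring. Compound 3 `Cc1nc2cc(OC[C@H](O)CN3CCN(Cc4noc(-c5ccc(Cl)cc5)n4)CC3)ccc2s1` carries chloro in place of isopropyl on an aromatic carbon, a further reduction of that same group. Should that single step carry over, compound 3 is expected to be weaker again, by about a 2.6-fold higher number from compound 2 to compound 3 (0.42 log units; beyond the scatter). For compound 3 the estimate in this assay is 2500 nM, within a range from 800 nM to 8000 nM.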

Compound 3, half-maximal inhibitory concentration: 2270 nM
Beside the measured number, compound 3's estimate is 1.1-fold (0.04 log units) above it, within the range that was stated.
By their numbers in this assay, from the lowest: compound 1; then compound 2; then compound 3.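

In this assay the loss continues with a 2.4-fold higher number from compound 2 to compound 3 (0.38 log units; beyond the scatter) and, taken over the whole change from tert-butyl to chloro, reaches a 13-fold higher number from compound 1 to compound 3 (1.10 log units; beyond the scatter). Across these three compounds the number rises in the order tert-butyl, isopropyl, chloro, and no compound goes against that order. Nothing available here explains this order.

As far as these compounds go, whether it holds for a group such as cyclohexyl, trifluoromethyl or an amine remains open. So does whether chloro belongs on the same trend as the two alkyl groups, since it is the only non-alkyl group shown.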